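Swapping a methylphenyl for a pyridyl: expected solubility

The source may report more compounds than this note shows. Statements on the series, on what has been measured and on what is new or still open speak of the compounds shown alone.

Measured so far:
compound 1, `Cn1cc(-c2cnc3[nH]cc(-c4ccc(C#N)cc4)c3c2)cn1`, 2000 nM
compound 2, `Cc1ccc(-c2c[nH]c3ncc(-c4cnn(C)c4)cc23)cc1`, 7000 nM

Both compounds were tested in a physicochemical assay for solubility, read by LC-MS, in phosphate buffer, measured as thermodynamic solubility, with a stated time of 24 h, at pH 7.4; a higher number here means a more soluble compound, a lower number a less soluble compound. Going by the values given here, compound 2 gives the higher of the two numbers; the only other compound, compound 1, sits below it by a step of a 3.5-fold higher number from compound 1 to compound 2 (0.54 log units; beyond the scatter), which came from a methyl in place of cyano on an aromatic carbon.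

The next compound, compound 3, `Cn1cc(-c2cnc3[nH]cc(-c4cccnc4)c3c2)cn1`, changes compound 2 in one place: pyridin-3-yl in place of 4-methylphenyl on an aromatic carbon. Among the compounds with values here, this is a different kind of change from the one measured step, which swapped a small substituent on the same ring rather than exchanging the whole ring. That step therefore bears on it only loosely: it shows that a single change at this part of the shared core moved the number modestly and beyond the scatter, without pointing to the direction for a ring exchange.

Compound 3 is expected to show a step of a 2.1-fold higher number from compound 2 to compound 3 (0.33 log units; beyond the scatter), a modest rise. Compound 3 is thus estimated at 15000 nM, with a range from 5000 nM to 50000 nM.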

Compound 3, solubility: 97000 nM
Compound 3: the middle estimate sits 6.5-fold (0.81 log units) below what was measured; measured number outside the range, above it.
By their numbers in this assay, from the lowest: compound 1; then compound 2; then compound 3.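

In this assay, exchanging the whole ring on this aromatic carbon gives a 14-fold higher number from compound 2 to compound 3 (1.14 log units; beyond the scatter), a large step, whereas the earlier swap of a small substituent on that ring gave a 3.5-fold higher number from compound 1 to compound 2 (0.54 log units; beyond the scatter), a modest one. This place on the shared core can therefore move the number far more than the first pair suggested, and a single ring exchange is enough to do it. The exchange makes several changes at once: pyridin-3-yl brings a ring nitrogen and a hydrogen-bond acceptor, while 4-methylphenyl brings a methyl and one more heavy atom, and no measurement here explains the size of the step or separates these changes.

An unsubstituted phenyl ring would help separate the loss of the methyl from the gain of the ring nitrogen, while pyridin-2-yl and pyridin-4-yl would test whether the location of that nitrogen matters. The compounds shown also leave open how a ring carrying a morpholine or a carboxylic acid would behave at this carbon.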